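This account rests on a few compounds, and the source may have more. Where it says the series, first, only, none or still open, it means among the compounds named here.

Working notes on the series, read in an ADME assay on cells (Lymphocyte, Homo sapiens) for cytotoxicity, read by MTT assay, with a stated time of 48 h; a lower number here means a stronger inhibitor, a higher number a weaker inhibitor. Compound 1 (`COC(=O)/C(=C\c1ccc(OC(=O)c2c(OC)cccc2OC)cc1)Sc1ccnc2cc(Cl)ccc12`) gives > 100000 nM, which is a limit and not a number. Among the measured compounds shown here, compound 2 (`COC(=O)/C(=C\c1ccc(OC(=O)c2cc(OC)c(OC)c(OC)c2)cc1)Sc1ccnc2cc(Cl)ccc12`) gives 35200 nM, the only true number so far. The change to compound 3 (`COC(=O)/C(=C\c1ccc(OC(=O)c2ccc(OC)c(OC)c2OC)cc1)Sc1ccnc2cc(Cl)ccc12`) is 2,3,4-trimethoxyphenyl in place of 3,4,5-trimethoxyphenyl on a carbonyl carbon, the same atoms joined differently. For the measured compounds named here, one measured step bears on it, an at least 2.8-fold lower number from compound 1 to compound 2 (0.45 log units; beyond the scatter), made on the same carbonyl carbon and beyond the scatter, though its full size stays open. The only other substitution measured there, in compound 1, lies on the higher side of compound 2, so a modest move towards a weaker inhibitor is expected. The expected change is a 1.7-fold higher number from compound 2 to compound 3 (0.23 log units; within the scatter). Compound 3 is estimated at 60000 nM, with an expected range of 25000 nM to 100000 nM.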

Compound 3, half-maximal inhibitory concentration: 22400 nM
Beside the measured number, compound 3's estimate is 2.7-fold (0.43 log units) above it; the whole stated range lies above it.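

In this assay the 2,3,4-trimethoxyphenyl and 3,4,5-trimethoxyphenyl groups on the carbonyl carbon, the same atoms joined differently, cannot be told apart: a 1.6-fold lower number from compound 2 to compound 3 (0.20 log units; within the scatter). The step from the 2,6-dimethoxyphenyl group to the 2,3,4-trimethoxyphenyl group is an at least 4.4-fold lower number from compound 1 to compound 3 (0.64 log units; beyond the scatter), so both trimethoxyphenyl groups shown now lie on the lower side of compound 1. Compound 1 stands at a limit and not a number, and the full size of that step stays open: the limit of > 100000 nM in this assay, at which 1 of the 3 values shown sits.

Still open, going by these compounds, is whether the count of methoxy groups or their arrangement sets the gap to compound 1, which differs from the other two in both. Also open, on these data alone, is how a phenyl ring carrying an amine or a carboxylic acid in place of the methoxy groups would read in this assay.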